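The source may report more compounds than this note shows. Statements on the series, on what has been measured and on what is new or still open speak of the compounds shown alone.

- compound 1 `COc1ccc(N(C)c2nc(C)nc3ccccc23)cc1C(=O)OCCCC[Se]C#N`: 662 nM
- compound 2 `COc1ccc(N(C)c2nc(C)nc3ccccc23)cc1C(=O)OCCCCCC[Se]C#N`: 1990 nM
- compound 3 `COc1ccc(N(C)c2nc(C)nc3ccccc23)cc1C(=O)OCCCCC[Se]C#N`: 551 nM

These three numbers come from a functional assay on HCT-116 cells (Homo sapiens) for inhibition, read by MTT assay, with a stated time of 48 h; a lower number here means a stronger inhibitor, a higher number a weaker inhibitor. Compound 1, at 662 nM, sits in the same range as compound 3, as the data show a 1.2-fold lower number from compound 1 to compound 3 (0.08 log units; within the scatter). Compound 2 stands apart, with a 3.0-fold higher number from compound 1 to compound 2 (0.48 log units; beyond the scatter).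

The next compound, compound 4 `COc1ccc(N(C)c2nc(C)nc3ccccc23)cc1OCCCCC[Se]C#N`, has not yet been measured. Its structural change from compound 1 is a group of 9 heavy atoms (6 carbon, 1 nitrogen, 1 oxygen, 1 selenium; no ring) in place of a group of 10 heavy atoms (6 carbon, 1 nitrogen, 2 oxygen, 1 selenium; no ring), on an aromatic carbon. The change lies on an aromatic carbon of a six-membered aromatic ring of carbon only, ortho to a methoxy group. The group that leaves holds a carbonyl, and the group that enters does not.

The measured steps bear on this change only in part, as all three alter the chain and keep the carbonyl. Besides the two above, there is a 3.6-fold lower number from compound 2 to compound 3 (0.56 log units; beyond the scatter). So the chain steps range from within the scatter to modest, and no measured step shows what removing the carbonyl does. The data therefore give no direction, and the range must stay wide.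

The estimated step is a 1.2-fold lower number from compound 1 to compound 4 (0.08 log units; within the scatter), so no change beyond the scatter is expected. Compound 4 is expected to give about 550 nM, with an estimated range of 140 nM to 2200 nM.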

Compound 4, half-maximal inhibitory concentration: 256 nM
For compound 4 the middle estimate is 2.1-fold (0.33 log units) above the measured one; the measured number falls inside the stated range.
By their numbers in this assay, from the lowest: compound 4; then compounds 3 and 1 (each within the scatter of the next); then compound 2.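

In this assay, the group holding a carbonyl on the aromatic carbon can give way to one without it, and the number does not rise but falls: a 2.6-fold lower number from compound 1 to compound 4 (0.41 log units; beyond the scatter). Going by these compounds alone, the earlier compounds all kept the carbonyl and changed only the chain, so this is the first sign that the carbonyl is not needed for activity at this position, at least in these cells. This step also alters the chain, but compound 3 carries the same chain as compound 4 and keeps the carbonyl: compound 3 gives 551 nM, while compound 4 gives 256 nM, and nothing available explains the gain in activity.

Among the carbonyl compounds, the longest chain, in compound 2, stood apart from the other two, and the compounds shown leave open whether a longer or shorter chain on the oxygen of compound 4 would behave the same way. They also leave open whether an amine in place of that oxygen, or sulfur in place of the selenium at the chain end, would keep the number this low.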